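Phenol ring swap on a hydrazone urea series

The compounds below may be only part of what the source reports. "The series", "measured", "known", "first", "only" and "open" are said of these compounds alone.

Measured compounds:
compound 1 `COc1ccc(/C=N/NC(=O)Nc2ccc(Oc3ccnc(-c4nncn4CCN(C)C)c3)c(F)c2)c(OC)c1` gives 1680 nM
compound 2 `COc1ccc(/C=N/NC(=O)Nc2ccc(Oc3ccnc(-c4nncn4CCN(C)C)c3)c(F)c2)cc1O` gives 2510 nM
compound 3 `CN(C)CCn1cnnc1-c1cc(Oc2ccc(NC(=O)N/N=C/c3ccc(O)cc3O)cc2F)ccn1` gives 2860 nM

All three share one core and differ only in the aromatic ring that hangs on the carbon double-bonded to nitrogen. In a functional assay on MKN-45 cells (Homo sapiens) for cytotoxicity, read by MTT assay, with a stated time of 72 h (a higher number here means a weaker inhibitor, a lower number a stronger inhibitor), compound 3 stands within the scatter of both neighbours: a 1.7-fold higher number from compound 1 to compound 3 (0.23 log units; within the scatter) and a 1.1-fold higher number from compound 2 to compound 3 (0.06 log units; within the scatter) are small, as is a 1.5-fold higher number from compound 1 to compound 2 (0.17 log units; within the scatter). Compound 4 `Cc1cc(/C=N/NC(=O)Nc2ccc(Oc3ccnc(-c4nncn4CCN(C)C)c3)c(F)c2)cc(C)c1O` carries the change (4-hydroxy-3,5-dimethylphenyl in place of 2,4-dihydroxyphenyl on a carbon with a double bond to nitrogen). Every measured swap of this ring left the number essentially unchanged, so the expected step for compound 4, a 1.1-fold lower number from compound 3 to compound 4 (0.06 log units; within the scatter), is none beyond the scatter. Compound 4 is therefore estimated at 2500 nM in this assay, with a likely range from 1000 nM to 6500 nM.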

Compound 4, half-maximal inhibitory concentration: 1510 nM
Estimate against measurement, compound 4: 1.7-fold (0.22 log units) above; the measured number falls inside the stated range.
By their numbers in this assay, from the lowest: compounds 4, 1, 2 and 3 (each within the scatter of the next).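

Placing 4-hydroxy-3,5-dimethylphenyl on this carbon, the only ring here with methyl groups, gives small steps against all three earlier rings: (a 1.9-fold lower number from compound 3 to compound 4 (0.28 log units; within the scatter)), (a 1.7-fold lower number from compound 2 to compound 4 (0.22 log units; within the scatter)) and (a 1.1-fold lower number from compound 1 to compound 4 (0.05 log units; within the scatter)). Within the data shown here, this ring has one hydrogen-bond donor in place of the two of 2,4-dihydroxyphenyl, yet no step leaves the scatter. Nothing available explains these small differences. Open, as far as these compounds go, are rings carrying an amine or a carboxylic acid, or a longer chain in place of the methyl groups, and any change to the shared core.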